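The source may hold more compounds than are shown below. What is called first, only, known or untested is meant among the compounds shown, and "the series" means these compounds.

Of the compounds shown here, three sharing one core have been measured in a functional assay on U-87MG ATCC cells for cytotoxicity against U-87 MG (Homo sapiens), read by colorimetric assay and MTT assay; on this read-out lower numbers stand for stronger inhibition and higher numbers for weaker inhibition. Compound 1 (`CCOC(=O)Cn1c(=O)c(-c2ccc(OC)cc2)cc2c(OC)cc(OC)cc21`) gives 10000 nM, compound 2 (`CCN(CC)C(=O)Cn1c(=O)c(-c2ccc(OC)cc2)cc2c(OC)cc(OC)cc21`) gives 10000 nM, and compound 3 (`COc1ccc(-c2cc3c(OC)cc(OC)cc3n(CCC#N)c2=O)cc1`) gives 10000 nM, so compound 3 stands level with the other two at the digits shown. The next compound, compound 4 (`COc1ccc(-c2cc3c(OC)cc(OC)cc3n(CCC(=O)OCc3ccccc3)c2=O)cc1`), alters the chain end of compound 3: benzyloxycarbonyl in place of cyano on a saturated chain carbon, two bonds along the chain from an aromatic nitrogen. In words, this is benzyloxycarbonyl in place of cyano on a saturated chain carbon, two bonds along the chain from an aromatic nitrogen.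

Among the compounds with values here, the steps that bear on this change are the three measured among the existing chain ends: no change at the digits printed from compound 1 to compound 2 (within the scatter), no change at the digits printed from compound 1 to compound 3 (within the scatter) and no change at the digits printed from compound 2 to compound 3 (within the scatter). All three are flat, so swapping ester, amide and nitrile ends has so far not moved this assay. Within the data shown here, none of the measured compounds carries the benzyloxycarbonyl group, so the effect of its six-membered aromatic ring remains untested, and the range has to stay open, more so towards stronger inhibition. With the flat step from compound 1 to compound 3 as the closest guide, no step beyond the scatter is expected, and the estimated outcome is no change at the digits printed from compound 3 to compound 4 (within the scatter). Compound 4 is estimated at 10000 nM, with an expected range of 4000 nM to 15000 nM.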

Compound 4, half-maximal inhibitory concentration: 10000 nM
Compound 4: middle estimate and measured number agree at the digits printed; the measured number falls inside the stated range.
By their numbers in this assay, from the lowest: compounds 1, 2, 3 and 4 (each within the scatter of the next).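

In this assay, within the data shown here, the benzyloxycarbonyl group puts an aromatic ring at this chain end for the first time, with 10 heavy atoms entering where the 2 of the cyano group leave, and the result is no change at the digits printed from compound 3 to compound 4 (within the scatter). Set against the diethylcarbamoyl and ethoxycarbonyl compounds, the same group gives no change at the digits printed from compound 2 to compound 4 (within the scatter) and no change at the digits printed from compound 1 to compound 4 (within the scatter), so among these four compounds neither the added six-membered aromatic ring nor the larger heavy-atom count at this place comes with any shift in the read-out. No supporting data are available to explain why the value holds across these chain ends.

As far as these compounds go, whether a carboxylic acid or a primary amine at the end of the chain, or a longer chain carrying the same benzyloxycarbonyl group, would give a different number remains open. Also open, from the compounds shown here alone, is whether a hydroxyl group in place of one of the methoxy groups on the shared core would shift the value, as all four compounds keep that core unchanged.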